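This account rests on a few compounds, and the source may have more. Where it says the series, first, only, none or still open, it means among the compounds named here.

Three esters on one quinone core have been run in a functional assay on HeLa cells (Homo sapiens) for cytotoxicity; a higher number here means a weaker inhibitor, a lower number a stronger inhibitor. Compound 1 `O=C(OC1=CC(=O)c2ccccc2C1=O)c1ccccc1` gives 55000 nM in this assay. Compound 2 `CC(=O)OC1=CC(=O)c2ccccc2C1=O` gives 62100 nM in this assay. Compound 3 `CC(=O)Oc1ccc2c(c1)C(=O)C=CC2=O` gives 27700 nM, the lowest of the three numbers, though its gap to compound 1 sits within the scatter and only its gap to compound 2 lies beyond it. Compound 3 and compound 2 hold the same atoms joined differently; the difference between the two cores is not broken down here.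

One change recurs twice in the set. From compound 2 to compound 1 it is phenyl in place of methyl on a carbonyl carbon and it brought a 1.1-fold lower number from compound 2 to compound 1 (0.05 log units; within the scatter). Compound 4 `O=C(Oc1ccc2c(c1)C(=O)C=CC2=O)c1ccccc1` is compound 3 carrying the same change, (phenyl in place of methyl on a carbonyl carbon), at a place described in the same words. Among the compounds with values here, the expectation is a flat step, a 1.1-fold lower number from compound 3 to compound 4 (0.03 log units; within the scatter), because the one earlier instance gave a 1.1-fold lower number from compound 2 to compound 1 (0.05 log units; within the scatter) and nothing else in the set bears on it. Compound 4 is therefore expected at 26000 nM in this assay, with a range from 11000 nM to 62000 nM.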

Compound 4, half-maximal inhibitory concentration: 19200 nM
Estimate against measurement, compound 4: 1.4-fold (0.13 log units) above; measured number inside the range.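

In this assay, phenyl in place of methyl on a carbonyl carbon gives a 1.4-fold lower number from compound 3 to compound 4 (0.16 log units; within the scatter), so the step is also flat on this second core. Set beside the earlier instance, the two steps agree: the same change on two cores in this assay, a 1.1-fold lower number (0.05 log units; within the scatter) from compound 2 to compound 1 and a 1.4-fold lower number (0.16 log units; within the scatter) from compound 3 to compound 4, 1.3-fold (0.11 log units) apart, within the scatter of two such steps. On these two cores the change therefore carries across without a step beyond the scatter, but this does not show that phenyl and methyl differ in their effect on the number, and two cores do not establish a rule for the wider series.

The compounds shown leave open whether a longer chain on the ester carbonyl, or a phenyl ring carrying an amine or a carboxylic acid, would move the number beyond the scatter. Also open, on these data alone, is whether an amide in place of the ester would keep the numbers of these two cores where they stand.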